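From a Nitrile to an Aniline on the Aryl Ether

The source may hold more compounds than are shown below. What is called first, only, known or untested is meant among the compounds shown, and "the series" means these compounds.

Two measured compounds share a core, shown for compound 1 as `COc1cc(C(C)=O)ccc1OCCCN1CCC(C(c2cccc(F)c2)c2cccc(F)c2)CC1`. In a functional assay (aorta) with Oryctolagus cuniculus as the target (a lower number here means tighter binding, a higher number weaker binding), compound 1 gives 3.16 nM. Compound 2, `COc1cc(C#N)ccc1OCCCN1CCC(C(c2ccc(F)cc2)c2ccc(F)cc2)CC1`, gives 2 nM in this assay, the lowest of the two numbers, though its gap to compound 1 lies within the scatter, so neither can be called the tighter binder on these data alone. The step from compound 2 leads to compound 3, `Nc1ccc(OCCCN2CCC(C(c3ccc(F)cc3)c3ccc(F)cc3)CC2)cc1`, which has yet to be measured. The change is 4-aminophenyl in place of 4-cyano-2-methoxyphenyl on an oxygen on a saturated carbon. Among the measured compounds shown here, no measured pair differing in one place is available, so no step size is on record to guide the estimate; the only reference is that compound 2 and compound 1 sit close together. Because compound 2 gives 2 nM, compound 3 is expected to land somewhat higher, with a step of a 3.0-fold higher number from compound 2 to compound 3 (0.48 log units; beyond the scatter) that may reach beyond the scatter. The estimate for compound 3 in this assay is 6 nM, within a range from 2 nM to 20 nM.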

Compound 3, dissociation constant: 31.6 nM
For compound 3 the middle estimate is 5.3-fold (0.72 log units) below the measured one, and the stated range ends below it.
By their numbers in this assay, from the lowest: compounds 2 and 1 (each within the scatter of the next); then compound 3.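

In this assay, 4-aminophenyl in place of 4-cyano-2-methoxyphenyl on an oxygen on a saturated carbon gives a 16-fold higher number from compound 2 to compound 3 (1.20 log units; beyond the scatter), a large step and the only one on record here, which shows that the group at this position is not interchangeable. The step belongs to the exchange as a whole: the nitrile and the methoxy leave together, the amine enters, the group shrinks from 10 heavy atoms to 7, and it gains a hydrogen-bond donor, so no single one of these differences can be credited with it. No supporting measurement bears on the size or direction of this step, and it stands here without an explanation.

Which of these differences carries the step stays open, and a phenyl bearing the nitrile alone or the methoxy alone on the same oxygen would begin to separate them. Also open, as far as these compounds go, is how an amide or a hydroxyl would fare in place of the amine, and whether a step of this size would hold on the core of compound 1.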